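From thiophen-2-yl to 4-nitrophenyl on a shared core

The compounds below may be only part of what the source reports. "The series", "measured", "known", "first", "only" and "open" are said of these compounds alone.

In a functional assay on MCF7 cells (Homo sapiens) for inhibition, read by MTT assay, with a stated time of 48 h (a lower number here means a stronger inhibitor, a higher number a weaker inhibitor), compound 2 (`O=C(CC(c1cccs1)C(C(=O)Nc1ccccn1)C(=O)Nc1ccccn1)c1ccccc1`) is reported as "not active" (no number reported) and so offers no number to start from. Among the compounds with values here, compound 1 (`O=C(CC(c1ccc(Cl)cc1)C(C(=O)Nc1ccccn1)C(=O)Nc1ccccn1)c1ccccc1`), with a six-membered aromatic ring of carbon only at the same place, gives 19100 nM and is the only numerical guide. Compound 3 (`O=C(CC(c1ccc([N+](=O)[O-])cc1)C(C(=O)Nc1ccccn1)C(=O)Nc1ccccn1)c1ccccc1`) is the next to be tested. The change (4-nitrophenyl in place of thiophen-2-yl on a saturated chain carbon bound to two saturated chain carbons) puts 4-nitrophenyl in place of thiophen-2-yl on a saturated chain carbon bound to two saturated chain carbons. In this assay a modest gain is expected, from no reported activity to weak activity. The estimated value for compound 3 is 20000 nM (7000 nM to 60000 nM).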

Compound 3, half-maximal inhibitory concentration: "not active" (no number reported)
For compound 3 the study gives words and no number; no gap can be computed for the estimate.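

Compound 2 and compound 3 are both reported only in words in this assay, so no step can be read between them. Within the data shown here, compound 1 gives 19100 nM as the only number, leaving open how far either compound lies from it. No measurement shown offers an explanation.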